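Trading One Aryl Group for Another on the Shared Core

The source may report more compounds than this note shows. Statements on the series, on what has been measured and on what is new or still open speak of the compounds shown alone.

Three compounds share one core and differ only in the aryl group attached to a saturated ring carbon. Compound 1 `CC(C)c1cccc(C(C)C)c1NC(=O)NCC1(c2ccc(Cl)cc2)CCCC1` gives 32 nM in an assay on microsomes for inhibition of acyl-CoA:cholesterol acyltransferase (Oryctolagus cuniculus); a higher number here means a weaker inhibitor, a lower number a stronger inhibitor. Compound 2 `COc1cccc(C2(CNC(=O)Nc3c(C(C)C)cccc3C(C)C)CCCC2)c1` gives 13 nM, and compound 3 `CC(C)c1cccc(C(C)C)c1NC(=O)NCC1(c2cccc(N(C)C)c2)CCCC1` gives 33 nM. Compound 3 thus stands alongside compound 1, the two being within the scatter of each other, while compound 2 sits clearly below both. The steps measured so far are all modest or nil: a 2.5-fold lower number from compound 1 to compound 2 (0.39 log units; beyond the scatter), a 1.0-fold higher number from compound 1 to compound 3 (0.01 log units; within the scatter) and a 2.5-fold higher number from compound 2 to compound 3 (0.40 log units; beyond the scatter). Compound 4 `COC(=O)c1ccc(C2(CNC(=O)Nc3c(C(C)C)cccc3C(C)C)CCCC2)cc1` is made from compound 3 by one change: 4-(methoxycarbonyl)phenyl in place of 3-(dimethylamino)phenyl on a saturated ring carbon. Every step in this assay that changes the aryl group has stayed within a narrow band, so a step of similar size, in either direction or none beyond the scatter, is expected here. For compound 4 the expected value in this assay is 30 nM, with a range from 10 nM to 90 nM, which corresponds to an expected step of a 1.1-fold lower number from compound 3 to compound 4 (0.04 log units; within the scatter).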

Compound 4, half-maximal inhibitory concentration: 360 nM
The estimate for compound 4 lay 12-fold (1.08 log units) below the measured number, and the stated range ends below it.
By their numbers in this assay, from the lowest: compound 2; then compounds 1 and 3 (each within the scatter of the next); then compound 4.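

Until now, swapping the aryl group on this saturated ring carbon had changed little, but that tolerance has a clear limit. In this assay, 4-(methoxycarbonyl)phenyl makes compound 4 the weakest inhibitor of the set, with an 11-fold higher number from compound 3 to compound 4 (1.04 log units; beyond the scatter) and a 28-fold higher number from compound 2 to compound 4 (1.44 log units; beyond the scatter) and also an 11-fold higher number from compound 1 to compound 4 (1.05 log units; beyond the scatter) in the same direction. The last of these steps is the most telling: a methoxycarbonyl group replaces chloro on an aromatic carbon, so a single substituent on the aryl ring separates a compound in the same range as compound 3 from a much weaker one, and no measurement here accounts for that difference.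

Going by these compounds, it remains open whether 3-(methoxycarbonyl)phenyl would give a similarly weak inhibitor. Also open, on these data alone, is what a carboxylic acid or a primary amide would give in place of the methoxycarbonyl group.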